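Isopropyl to ethyl on the ring amine: solubility outlook

This account rests on a few compounds, and the source may have more. Where it says the series, first, only, none or still open, it means among the compounds named here.

Three compounds of the series have been run in a physicochemical assay for solubility, read by HPLC, in phosphate buffer, measured as kinetic solubility, with a stated time of 1 h, at pH 7.4, tested at 250 uM; on this read-out higher numbers stand for higher solubility and lower numbers for lower solubility. Compound 1 `CC(C)N1CCC(c2ccc3c(c2)oc(=O)n3C(=O)NCCCCc2ccccc2)CC1` gives 50000 nM in this assay. Compound 3 `O=C(NCCCCc1ccccc1)n1c2c(oc1=O)CCNC2` gives 82000 nM in this assay; the two numbers lie within the usual scatter of each other, so no order between compound 1 and compound 3 is claimed. Compound 2 `CC(C)CNC(=O)n1c(=O)oc2cc(C3CCCN(C)C3)ccc21` returns only a limit of the assay and not a number, > 250000 nM (the limit of > 250000 nM in this assay, at which 1 of the 3 values shown sits). Of the two actual numbers, compound 1 stands at the lower end, with compound 3 the nearest.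

For the measured compounds named here, no pair of measured compounds differs at a single place, so no measured step is available to lean on. Compound 4 `CCN1CCC(c2ccc3c(c2)oc(=O)n3C(=O)NCCCCc2ccccc2)CC1` is not yet measured. It differs from compound 1 in one place: hydrogen in place of methyl on a saturated chain carbon bound to an amine nitrogen in a ring and a saturated chain carbon. Read one bond further out, isopropyl becomes ethyl, and 1-isopropylpiperidin-4-yl becomes 1-ethylpiperidin-4-yl.

With a single carbon leaving and no measured step of this kind in hand, the change is expected to be small, if anything toward a higher number, and most likely not beyond the scatter. Compound 4 is expected to give 65000 nM in this assay, with a range from 30000 nM to 140000 nM. The step that this estimate means, a 1.3-fold higher number from compound 1 to compound 4 (0.11 log units; within the scatter), is expected to stay within the scatter.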

Compound 4, solubility: 198000 nM
For compound 4 the middle estimate is 3.0-fold (0.48 log units) below the measured one; the measured number lies above the stated range.
By their numbers in this assay, from the lowest: compounds 1 and 3 (each within the scatter of the next); then compound 4. At a limit, above all of these: compound 2.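

In this assay, the ring amine substituent turns out to be a position where a small edit can register: isopropyl to ethyl, with one carbon leaving and no ring, donor, acceptor or net charge involved, gives a 4.0-fold higher number from compound 1 to compound 4 (0.60 log units; beyond the scatter). For the compounds shown here, the earlier compounds offered no pair differing in one place, so this is the first measured single-change step, and it lies beyond the usual scatter, showing that 1-isopropylpiperidin-4-yl and 1-ethylpiperidin-4-yl are not interchangeable on this read-out. Going by these compounds alone, nothing measured so far gives a cause for a step of this size.

This single step leaves open whether the number keeps moving in the same direction with a methyl-free ring amine bearing only hydrogen, or with a cyclopropyl or a longer propyl chain in the same place, and whether the step carries over when the phenylbutyl urea side chain is replaced. Compound 2 remains a limit of the assay and cannot be placed by number: the limit of > 250000 nM in this assay, at which 1 of the 4 values shown sits.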